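Moving the Chlorine on the Benzyl Arm

The compounds below may be only part of what the source reports. "The series", "measured", "known", "first", "only" and "open" are said of these compounds alone.

Measured so far:
compound 1 `Cc1[nH]n(-c2nc3ccccc3[nH]2)c(=O)c1Cc1ccccc1Cl`: -13%
compound 2 `O=c1c(Cc2ccccc2)c(-c2ccccc2)[nH]n1-c1nc2ccccc2[nH]1`: 2%

In an assay on isolated protein for inhibition of alpha-ketoglutarate-dependent dioxygenase alkB homolog 3 (Homo sapiens), read by polymerase chain reaction, with a stated time of 1 h, tested at 10 mM (on this read-out lower numbers stand for less inhibition and higher numbers for more inhibition at the one concentration tested (going by the name of the read-out)), compound 1 gives -13%, the lowest of the two numbers. Compound 2 gives 2%, a reading beyond the usual scatter above compound 1, though the two differ in more than one place, so nothing is known about any single change between them. Compound 3 `Cc1[nH]n(-c2nc3ccccc3[nH]2)c(=O)c1Cc1ccc(Cl)cc1` differs from compound 1 only by 4-chlorophenyl in place of 2-chlorophenyl on a saturated chain carbon bound to an aromatic carbon. For the measured compounds named here, no measured pair shows this kind of change, so its effect is unknown. Compound 3 is expected to stay near compound 1 because compound 1 gives -13%, a reading that shows essentially no inhibition. The step of a number 8 percentage points higher from compound 1 to compound 3 (within the scatter) is thus expected to lie within the scatter. Compound 3 is estimated at -5%, between -20% and 15%.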

Compound 3, a percentage reported as inhibition, at one concentration (the size of the read-out at that concentration, not a potency): 46%
The estimate for compound 3 lay 51 percentage points below the measured number; measured number outside the range, above it.
By their numbers in this assay, from the lowest: compound 1; then compound 2; then compound 3.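

In this assay moving the chlorine alone gives a number 59 percentage points higher from compound 1 to compound 3 (beyond the scatter) and so shows that its place on the benzyl arm matters strongly in this series. The 2-chlorophenyl and 4-chlorophenyl groups have the same atoms and the same counts, so those counts cannot separate them. Nothing available explains the difference. Going by these compounds, whether the chlorine itself is needed remains open. So does how a bromine, a methoxy group or an amine would read in place of the chlorine of the 4-chlorobenzyl group.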